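The source may hold more compounds than are shown below. What is called first, only, known or untested is meant among the compounds shown, and "the series" means these compounds.

Compound 2 `CCCCNc1nc(C)nc2c1nnn2-c1ccc(C(C)C)cc1Br` and compound 1 `CCC(COC)N(C)c1nc(C)nc2c1nnn2-c1ccc(C(C)C)cc1Br` share one core and differ only in the group carried on the nitrogen attached to it. Among the measured compounds shown here, in an in vitro assay on 293-EBNA cells for binding affinity to corticotropin-releasing factor receptor 1 (Homo sapiens) (a higher number here means a weaker inhibitor, a lower number a stronger inhibitor), compound 1 gives 11.2 nM, while compound 2 gives 69.6 nM; the step between them is a 6.2-fold higher number from compound 1 to compound 2 (0.79 log units; beyond the scatter), so compound 2 holds the higher of the two numbers so far, meaning the weaker binding. For the measured compounds named here, compound 3 `CCCCC(CC)Nc1nc(C)nc2c1nnn2-c1ccc(C(C)C)cc1Br` keeps the core of compound 2 and alters only that same group: 1-ethylpentyl in place of butyl on a nitrogen on an aromatic ring. Going by the values given here, the one measured step that bears on this change is the step from compound 1 to compound 2, where a smaller group replaced a larger one and the number rose modestly; the present change runs the other way, enlarging the group again. A modest fall in the number is therefore expected, a 2.8-fold lower number from compound 2 to compound 3 (0.44 log units; beyond the scatter). For compound 3 the value in this assay is estimated at 25 nM, with a range from 7 nM to 90 nM.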

Compound 3, inhibition constant: 3.1 nM
Beside the measured number, compound 3's estimate is 8.1-fold (0.91 log units) above it; measured number outside the range, below it.
By their numbers in this assay, from the lowest: compound 3; then compound 1; then compound 2.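

In this assay, replacing butyl with 1-ethylpentyl on the nitrogen gives a 22-fold lower number from compound 2 to compound 3 (1.35 log units; beyond the scatter), a large step that shows this position can take a bigger carbon-only group with a marked gain in binding. The earlier pair suggested that a bigger group could help, but its larger group also contained oxygen. Compound 3 now shows that oxygen is not required: its group has the same heavy-atom count as the group in compound 1, and the change gives a 3.6-fold lower number from compound 1 to compound 3 (0.56 log units; beyond the scatter), leaving compound 3 with the lowest number of the three.

No evidence here explains why these numbers fall. Going by these compounds, it also remains open whether the added carbons or the branching matter more, which a straight heptyl chain on the same nitrogen could help separate.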